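Benzyloxycarbonyl for methyl on a chloro-bearing analogue

The source may report more compounds than this note shows. Statements on the series, on what has been measured and on what is new or still open speak of the compounds shown alone.

The series rests on a shared core carried by compound 1 `Cc1ccc2[nH]c(-c3cn(-c4ccccc4)nc3-c3ccccc3)nc2c1`, compound 2 `O=C(OCc1ccccc1)c1ccc2[nH]c(-c3cn(-c4ccccc4)nc3-c3ccccc3)nc2c1` and compound 3 `Cc1ccc2[nH]c(-c3cn(-c4ccccc4)nc3-c3ccc(Cl)cc3)nc2c1`, with compound 4 `O=C(OCc1ccccc1)c1ccc2[nH]c(-c3cn(-c4ccccc4)nc3-c3ccc(Cl)cc3)nc2c1` not yet measured. In a functional assay on MCF7 cells (Homo sapiens) for antiproliferative activity, read by MTT assay, with a stated time of 48 h (on this read-out higher numbers stand for weaker inhibition and lower numbers for stronger inhibition), compound 1 gives 5940 nM. Compound 2 gives 12600 nM in this assay, and compound 3 gives 8230 nM.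

The change from compound 1 to compound 2 is benzyloxycarbonyl in place of methyl on an aromatic carbon; it produced a 2.1-fold higher number from compound 1 to compound 2 (0.33 log units; beyond the scatter). The cores of compound 1 and compound 3 differ by chloro in place of hydrogen on an aromatic carbon, with a 1.4-fold higher number from compound 1 to compound 3 (0.14 log units; within the scatter). The change from compound 3 to compound 4 is benzyloxycarbonyl in place of methyl on an aromatic carbon, the same change as from compound 1 to compound 2, made here on the core of compound 3. It occurs twice among these compounds.

For compound 4 a step of a 2.1-fold higher number from compound 3 to compound 4 (0.32 log units; beyond the scatter) is expected in this assay because a 2.1-fold higher number from compound 1 to compound 2 (0.33 log units; beyond the scatter) was measured for the same change on a core that differs only by the chloro of compound 3. On that basis compound 4 is estimated at 17000 nM, with a range from 9000 nM to 35000 nM.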

Compound 4, half-maximal inhibitory concentration: 13900 nM
Beside the measured number, compound 4's estimate is 1.2-fold (0.09 log units) above it; measured number inside the range.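

In this assay, benzyloxycarbonyl in place of methyl on the chloro-bearing core gives a 1.7-fold higher number from compound 3 to compound 4 (0.23 log units; within the scatter), and this step agrees with the one measured on the core of compound 1: the same change on two cores in this assay, a 2.1-fold higher number (0.33 log units; beyond the scatter) from compound 1 to compound 2 and a 1.7-fold higher number (0.23 log units; within the scatter) from compound 3 to compound 4, 1.3-fold (0.10 log units) apart, within the scatter of two such steps

Chloro in place of hydrogen, read on the benzyloxycarbonyl-bearing core, gives a 1.1-fold higher number from compound 2 to compound 4 (0.04 log units; within the scatter), and this too agrees with its earlier counterpart: the same change on two cores in this assay, a 1.4-fold higher number (0.14 log units; within the scatter) from compound 1 to compound 3 and a 1.1-fold higher number (0.04 log units; within the scatter) from compound 2 to compound 4, 1.3-fold (0.10 log units) apart, within the scatter of two such steps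

Among the compounds shown here, both changes therefore carry from one core to the other within these four compounds, but that rests on only two cores, and the step to compound 4 taken alone lies within the scatter, so it does not establish a separate effect of benzyloxycarbonyl on the chloro-bearing core, nor does it explain the agreement.

On these data alone, it remains open whether a carboxylic acid or a primary amide on the same aromatic carbon would follow the benzyloxycarbonyl step. As far as these compounds go, it is equally open whether a methoxy or fluoro in place of the chloro would leave the steps on these cores in agreement.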